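Ether replaces branched alkylamine on the shared core

The source may report more compounds than this note shows. Statements on the series, on what has been measured and on what is new or still open speak of the compounds shown alone.

Measured in an in vitro assay on 293-EBNA cells for binding affinity to corticotropin-releasing factor receptor 1 (Homo sapiens); on this read-out higher numbers stand for weaker inhibition and lower numbers for stronger inhibition:
compound 1, `CCN(CC)c1nc(C)nc2c1nnn2-c1ccc(C(C)C)cc1Br`: 25.3 nM
compound 2, `CCCCN(CC)c1nc(C)nc2c1nnn2-c1ccc(C(C)C)cc1Br`: 7.5 nM
compound 3, `CCCCC(CC)Nc1nc(C)nc2c1nnn2-c1ccc(C(C)C)cc1Br`: 3.1 nM

Compound 3 has the lowest number of the three, set apart by a 2.4-fold lower number from compound 2 to compound 3 (0.38 log units; beyond the scatter) and by an 8.2-fold lower number from compound 1 to compound 3 (0.91 log units; beyond the scatter). Compound 4, `COCC(COC)Oc1nc(C)nc2c1nnn2-c1ccc(C(C)C)cc1Br`, differs from compound 3 by a group of 8 heavy atoms (5 carbon, 3 oxygen; no ring) in place of a group of 8 heavy atoms (7 carbon, 1 nitrogen; no ring), on an aromatic carbon. The measured steps all concern lengthening or branching of the alkyl groups on that nitrogen, as in a 3.4-fold lower number from compound 1 to compound 2 (0.53 log units; beyond the scatter); none exchanges the nitrogen and its hydrogen-bond donor for an oxygen-rich chain, so they bear on this change only loosely. Because an 8.2-fold lower number from compound 1 to compound 3 (0.91 log units; beyond the scatter) shows that the gains in this series came with larger alkyl groups, compound 4 is expected to give a weaker result, estimated as a 13-fold higher number from compound 3 to compound 4 (1.11 log units; beyond the scatter), at 40 nM in this assay, within 8 nM to 200 nM.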

Compound 4, inhibition constant: 7.1 nM
Beside the measured number, compound 4's estimate is 5.6-fold (0.75 log units) above it; the whole stated range lies above it.
By their numbers in this assay, from the lowest: compound 3; then compounds 4 and 2 (each within the scatter of the next); then compound 1.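

In this assay this aromatic carbon keeps a low number without the nitrogen and its hydrogen-bond donor: replacing (1-ethylpentyl)amino with the ether chain gives a 2.3-fold higher number from compound 3 to compound 4 (0.36 log units; beyond the scatter) and the comparison with the butyl(ethyl)amino group gives a 1.1-fold lower number from compound 2 to compound 4 (0.02 log units; within the scatter). The earlier compounds shown here varied only alkyl groups on nitrogen, whereas this chain, with 0 hydrogen-bond donors and 3 hydrogen-bond acceptors, still improves on the diethylamino group, with a 3.6-fold lower number from compound 1 to compound 4 (0.55 log units; beyond the scatter). An amine bearing the same methoxy arms, or a plain alkyl ether, would separate the linking oxygen from the methoxy groups. No evidence at hand accounts for this result.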